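This account rests on a few compounds, and the source may have more. Where it says the series, first, only, none or still open, it means among the compounds named here.

Going by the values given here, in a functional assay for inhibition, with Homo sapiens as the target (a higher number here means weaker binding, a lower number tighter binding), three compounds have numbers so far. Compound 1 (`O=C(O)CC/C=C\CC1COC(c2ccc([N+](=O)[O-])cc2)OC1c1cccnc1`) stands at 933 nM and compound 2 (`O=C(O)CC/C=C\CC1COC(c2cccs2)OC1c1cccnc1`) at 1000 nM while compound 3 (`COc1ccc(OC(C)(C)C2OCC(C/C=C\CCC(=O)O)C(c3cccnc3)O2)cc1`) gives the lowest number of the three (302 nM), beyond the scatter from both others. Compound 4 (`CSc1ccccc1OC(C)(C)C1OCC(C/C=C\CCC(=O)O)C(c2cccnc2)O1`) has no number yet. It differs from compound 3 in one place (2-(methylsulfanyl)phenyl in place of 4-methoxyphenyl on an oxygen on a saturated carbon) with 2-(methylsulfanyl)phenyl in place of 4-methoxyphenyl on an oxygen on a saturated carbon. Among the compounds with values here, no measured step tests a change at this place. Within the data shown here, the only single-place step available is a 1.1-fold higher number from compound 1 to compound 2 (0.03 log units; within the scatter) and it lies within the scatter, but it concerns a different place, a saturated ring carbon, so it offers only weak guidance. With no direct evidence for a shift in either direction, no step beyond the scatter is expected in this assay here. The expected change is a 1.1-fold lower number from compound 3 to compound 4 (0.03 log units; within the scatter) and the range is kept wide to reflect how little bears on it. The estimate for compound 4 is 280 nM (range 100 nM to 800 nM).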

Compound 4, dissociation constant: 89.1 nM
Beside the measured number, compound 4's estimate is 3.1-fold (0.50 log units) above it; the whole stated range lies above it.
By their numbers in this assay, from the lowest: compound 4; then compound 3; then compounds 1 and 2 (each within the scatter of the next).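

In this assay, going by these compounds alone, putting 2-(methylsulfanyl)phenyl in place of 4-methoxyphenyl on an oxygen on a saturated carbon gives a 3.4-fold lower number from compound 3 to compound 4 (0.53 log units; beyond the scatter), so the number responds to a change at this place, which the only earlier step, made at a different place, could not show. The two groups have the same count of heavy atoms and differ in composition only by sulfur in place of oxygen, so a swap this small is already enough to move the number beyond the scatter. No measurement shown here explains the shift.

Sulfur for oxygen and the move from 4 to 2 in the group's name come together in this one step, and it cannot separate them. On these data alone, how an unsubstituted phenyl or a 2-chlorophenyl would compare at this place remains open.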